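This account rests on a few compounds, and the source may have more. Where it says the series, first, only, none or still open, it means among the compounds named here.

Compound 1 `COc1ccccc1N1C(=O)CSC1c1cccc(C(=O)Nc2ccccc2)c1`: > 25000 nM, a limit
Compound 2 `COc1ccccc1N1C(=O)CSC1c1cccc(C(=O)NCc2ccccc2)c1`: > 25000 nM, a limit

In a functional assay on MDA-MB-231 cells (Homo sapiens) for antiproliferative activity, read by sulforhodamine B assay, with a stated time of 48 h (a lower number here means a stronger inhibitor, a higher number a weaker inhibitor), compound 2 stands at > 25000 nM, which is a limit of the assay and not a number. Within the data shown here, the evidence so far is the limit of > 25000 nM in this assay, at which 2 of the 2 values shown sit, so the one measured step, a step that the two limits leave unreadable from compound 1 to compound 2, has no readable size. Compound 3 `COc1ccccc1N1C(=O)CSC1c1cccc(C(=O)NCCCc2ccccc2)c1` differs from compound 2 by phenethyl in place of phenyl on a saturated chain carbon bound to an amide-type nitrogen: phenethyl in place of phenyl, or benzyl to 3-phenylpropyl. Among the measured compounds shown here, with no sized step to go on, no step beyond the scatter is expected in this assay. The expected step is a step that the limit leaves unreadable from compound 2 to compound 3. Compound 3 is estimated at 30000 nM, with an expected range of 12000 nM to 75000 nM.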

Compound 3, half-maximal inhibitory concentration: 12300 nM
Compound 3: the middle estimate sits 2.4-fold (0.39 log units) above what was measured; measured number inside the range.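

Among these compounds, compound 3, with a 3-phenylpropyl group on the amide nitrogen, is the first compound here to give a number and not a limit in this assay. Benzyl to 3-phenylpropyl gives an at least 2.0-fold lower number from compound 2 to compound 3 (0.30 log units; that floor lies within the scatter), and phenyl to 3-phenylpropyl gives an at least 2.0-fold lower number from compound 1 to compound 3 (0.30 log units; that floor lies within the scatter). Both steps start from a limit of the assay, so they are floors only, and a longer link on this nitrogen has yet to show a true size of gain.

Still open, going by these compounds, is whether a longer chain, such as 4-phenylbutyl, would lower the number further. Also open, on these data alone, is whether an amine or a carboxylic acid at the chain end could replace the phenyl ring.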